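Trimming the sulfonamide side chain from compound 2 to compound 4

A few compounds are considered here, and "the series" means these few. Any claim that something is new, unique, unknown or untested is made for them only; others in the source may bear on it.

Of the compounds shown here, three have been measured in a functional assay on A549 cells (Homo sapiens) for antiproliferative activity, read by CCK-8 assay, with a stated time of 72 h; a lower number here means a stronger inhibitor of growth, a higher number a weaker inhibitor of growth. Compound 1 `CCC1C(=O)N(C)c2cnc(-n3ccc4cc(C(N)=O)ccc43)nc2N1c1ccn(C)n1` gives 39500 nM, and compound 3 `CCC1C(=O)N(C)c2cnc(-n3ccc4cc(C(=O)NC)ccc43)nc2N1c1ccn(C)n1` gives 43100 nM; these two differ only by a 1.1-fold higher number from compound 1 to compound 3 (0.04 log units; within the scatter), a change that does not move the number. Compound 2 `CC[C@@H]1C(=O)N(C)c2cnc(Nc3ccc(S(=O)(=O)NCCO)cc3)nc2N1C1CCCC1` gives 563 nM and stands lowest of the three, well beyond the scatter from both compound 1 and compound 3.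

Compound 4 `CC[C@@H]1C(=O)N(C)c2cnc(Nc3ccc(S(N)(=O)=O)cc3)nc2N1C1CCCC1` is not yet measured. It differs from compound 2 by hydrogen in place of 2-hydroxyethyl on a sulfonamide nitrogen. Going by the values given here, no measured step bears on this kind of change: the one step on record, from compound 1 to compound 3, is a small change on a different nitrogen in a different core, and it stayed within the scatter. With nothing that speaks for a large shift, the expectation for a 1.2-fold higher number from compound 2 to compound 4 (0.09 log units; within the scatter) is a step of modest size, and the direction is uncertain. Compound 4 is therefore estimated at 700 nM in this assay, within a range from 250 nM to 2000 nM.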

Compound 4, concentration for 50% growth inhibition: 3390 nM
Beside the measured number, compound 4's estimate is 4.8-fold (0.69 log units) below it; the whole stated range lies below it.
By their numbers in this assay, from the lowest: compound 2; then compound 4; then compounds 1 and 3 (each within the scatter of the next).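

Replacing 2-hydroxyethyl with hydrogen on the sulfonamide nitrogen gives a 6.0-fold higher number from compound 2 to compound 4 (0.78 log units; beyond the scatter) in this assay and leaves a bare sulfamoyl group. Going by these compounds alone, the only earlier step, on an amide-type nitrogen in a different core, stayed within the scatter, so this pair gives the first sign that a single small change can move the number, and here the substituent on the sulfonamide nitrogen goes with the lower number. Nothing available here explains why the number rises.

One pair cannot show whether the hydroxyl group or the ethyl chain that carries it accounts for this step. A plain ethyl group, a longer chain such as 3-hydroxypropyl, or a 2-aminoethyl group on the same nitrogen would help to separate those two parts.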